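Oral exposure notes: from compound 3 to compound 4

The source may hold more compounds than are shown below. What is called first, only, known or untested is meant among the compounds shown, and "the series" means these compounds.

Three compounds on the shared core have numbers in an ADME assay on the whole organism (strain FVB) for pharmacokinetics, with Mus musculus as the target, read by LC-MS, at a dose of 30 mg/kg by the oral route; on this read-out lower numbers stand for lower exposure and higher numbers for higher exposure at the dose given. Compound 1 `NCCOc1ccc([C@H]2CC[C@]3(CC2)OOC2(O3)C3CC4CC(C3)CC2C4)cc1` gives 287 nM in this series, compound 2 `CC(C)(O)CNCCCOc1ccc([C@H]2CC[C@]3(CC2)OOC2(O3)C3CC4CC(C3)CC2C4)cc1` gives 1210 nM and compound 3 `CC(C)(O)CN1CCC(Oc2ccc([C@H]3CC[C@]4(CC3)OOC3(O4)C4CC5CC(C4)CC3C5)cc2)CC1` gives 1810 nM on the same read-out.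

Compound 3 sits level with compound 2 (a 1.5-fold higher number from compound 2 to compound 3 (0.17 log units; within the scatter)) and clear of compound 1 (a 6.3-fold higher number from compound 1 to compound 3 (0.80 log units; beyond the scatter)).

Compound 4 `c1cc([C@H]2CC[C@]3(CC2)OOC2(O3)C3CC4CC(C3)CC2C4)ccc1OCCC1CCNCC1` carries 2-(piperidin-4-yl)ethyl in place of 1-(2-hydroxy-2-methylpropyl)piperidin-4-yl on an oxygen on an aromatic ring.

Among the measured compounds shown here, two measured steps bear on this change, a 4.2-fold higher number from compound 1 to compound 2 (0.62 log units; beyond the scatter) and a 6.3-fold higher number from compound 1 to compound 3 (0.80 log units; beyond the scatter), each leading to a compound that carries 2-hydroxy-2-methylpropyl. Compound 4, like compound 1, lacks that group, but it keeps a piperidine ring, so it is not expected to fall the whole way back to the number of compound 1. For the measured compounds named here, no measured pair isolates the group on a piperidine, which leaves the size of the step uncertain.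

A fall is expected, with the estimated change being a 2.6-fold lower number from compound 3 to compound 4 (0.41 log units; beyond the scatter) in this assay (a moderate step, smaller than those two measured steps).

For compound 4 the estimate is 700 nM in this assay (expected range 250 nM to 2000 nM).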

Compound 4, maximal plasma concentration: 1190 nM
Compound 4: middle estimate off by 1.7-fold (0.23 log units), on the low side; the measured number falls inside the stated range.
By their numbers in this assay, from the lowest: compound 1; then compounds 4, 2 and 3 (each within the scatter of the next).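

In this assay, replacing 1-(2-hydroxy-2-methylpropyl)piperidin-4-yl with 2-(piperidin-4-yl)ethyl on the oxygen on the aromatic ring gives a 1.5-fold lower number from compound 3 to compound 4 (0.18 log units; within the scatter), and the comparison with the open-chain amine gives a 1.0-fold lower number from compound 2 to compound 4 (0.01 log units; within the scatter), so compounds 2, 3 and 4 stand level despite their different groups at this position. Until now, both numbers clear of compound 1 belonged to compounds carrying 2-hydroxy-2-methylpropyl, but piperidin-4-yl in place of amino on the saturated chain carbon gives a 4.1-fold higher number from compound 1 to compound 4 (0.62 log units; beyond the scatter), which shows that this group is not required for a number clear of compound 1 among the compounds shown. Nothing available accounts for the level standing of these three compounds or for the separate standing of compound 1.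

From the compounds shown here alone, it remains open what 2-hydroxy-2-methylpropyl would do on the nitrogen of the 2-(piperidin-4-yl)ethyl group itself, since the present comparisons change that group together with the link to the oxygen. Also open, going by these compounds, is how a morpholine, a dimethylamino group or a longer chain ending in piperidin-4-yl would stand against compound 4 on this read-out.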